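The compounds below may be only part of what the source reports. "The series", "measured", "known", "first", "only" and "open" are said of these compounds alone.

Measured so far:
- compound 1, `O=C(NCc1cn(Cc2ccc(C(F)(F)F)cc2)nn1)c1cn(-c2ccccc2)nc1-c1ccc(Cl)cc1`: 4900 nM
- compound 2, `COc1ccc(Cn2cc(CNC(=O)c3cn(-c4ccccc4)nc3-c3ccc(Cl)cc3)nn2)cc1`: 8000 nM
- compound 3, `COc1ccc(-c2nn(-c3ccccc3)cc2C(=O)NCc2cn(Cc3ccc(C(F)(F)F)cc3)nn2)cc1`: > 100000 nM

All three were tested in a functional assay on MCF7 cells (Homo sapiens) for antiproliferative activity, read by sulforhodamine B assay, with a stated time of 48 h; on this read-out higher numbers stand for weaker inhibition of growth and lower numbers for stronger inhibition of growth. Compound 1 gives 4900 nM. Compound 2 gives 8000 nM. For compound 3 the value of > 100000 nM is a limit of the assay and not a number.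

Compound 1 and compound 2 differ in one place, (methoxy in place of trifluoromethyl on an aromatic carbon). This change gives a 1.6-fold higher number from compound 1 to compound 2 (0.21 log units; within the scatter). Compound 1 and compound 3 differ in another place, (methoxy in place of chloro on an aromatic carbon). Here the step is an at least 20-fold higher number from compound 1 to compound 3 (1.30 log units; beyond the scatter), and the value reached by compound 3 is the limit of > 100000 nM in this assay, at which 1 of the 3 values shown sits.

Compound 4, `COc1ccc(Cn2cc(CNC(=O)c3cn(-c4ccccc4)nc3-c3ccc(OC)cc3)nn2)cc1`, has not yet been measured in this assay. Among the compounds with values here, it differs from compound 3 by methoxy in place of trifluoromethyl on an aromatic carbon, which is the same change as the one from compound 1 to compound 2, in the same place around the ring. Compound 4 also carries the core of compound 3, which ended at the limit of the assay.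

On this basis, compound 4 is expected to stay at or beyond the limit of the assay, since the same change between compound 1 and compound 2 gave only a 1.6-fold higher number from compound 1 to compound 2 (0.21 log units; within the scatter), and the core of compound 3 already sits at the limit shown by the limit of > 100000 nM in this assay, at which 1 of the 3 values shown sits. The estimated step from compound 3 to compound 4 is a step that the limit leaves unreadable from compound 3 to compound 4. The estimate for compound 4 in this assay is 200000 nM, with an expected range from 100000 nM to 1000000 nM.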

Compound 4, concentration for 50% growth inhibition: 22900 nM
The estimate for compound 4 lay 8.7-fold (0.94 log units) above the measured number, outside the stated range (below it).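

In this assay, the change from 4-(trifluoromethyl)benzyl to 4-methoxybenzyl gave an at least 4.3-fold lower number from compound 3 to compound 4 (0.64 log units; beyond the scatter), so it did not repeat on the second core what it had done on the first: the same change on two cores in this assay, a 1.6-fold higher number (0.21 log units; within the scatter) from compound 1 to compound 2 and an at least 4.3-fold lower number (0.64 log units; beyond the scatter) from compound 3 to compound 4, at least 7.1-fold (0.85 log units) apart, beyond the scatter of two such steps. The change of chloro to methoxy gave a 2.9-fold higher number from compound 2 to compound 4 (0.46 log units; beyond the scatter), which points the same way as its earlier step on the other core but differs from it in size: the same change on two cores in this assay, an at least 20-fold higher number (1.30 log units; beyond the scatter) from compound 1 to compound 3 and a 2.9-fold higher number (0.46 log units; beyond the scatter) from compound 2 to compound 4, at least 7.1-fold (0.85 log units) apart, beyond the scatter of two such steps. Compound 3 gives > 100000 nM, which is a limit of the assay and not a number, so both gaps are minimum sizes; they show that in these four compounds the effect of one change depends on the group present at the other place, but they do not show why, and they give no rule for other cores.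

The compounds shown leave open whether this dependence also appears with other groups in the same places, such as fluoro or methyl in place of chloro, or an amine or a carboxylic acid in place of methoxy. They also leave open what a longer chain in place of the methoxy on either ring would do in this assay.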